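This account rests on a few compounds, and the source may have more. Where it says the series, first, only, none or still open, it means among the compounds named here.

In a functional assay on A-375 cells (Homo sapiens) for activation, with a stated time of 3 days (on this read-out lower numbers stand for an effect already at smaller amounts and higher numbers for an effect only at larger amounts of compound), three compounds have been measured so far:

Compound 1 `O=C(Nc1ccc(-c2cscn2)cc1)C1CCCN(Cc2ccc(F)c(F)c2)C1`: 1240 nM
Compound 2 `O=C(Nc1ccc(-c2ccncc2)cc1)C1CCCN(Cc2ccc(F)c(F)c2)C1`: 1180 nM
Compound 3 `O=C(Nc1ccc(-c2c[nH]cn2)cc1)C1CCCN(Cc2ccc(F)c(F)c2)C1`: 16000 nM

Compound 3 has the highest number of the three, so it needs the largest amount to show an effect. Compound 4 `O=C(Nc1ccc(-c2ccsc2)cc1)C1CCCN(Cc2ccc(F)c(F)c2)C1` has not yet been measured. It differs from compound 3 in one place: thiophen-3-yl in place of 1H-imidazol-4-yl on an aromatic carbon. In words, thiophen-3-yl stands in place of 1H-imidazol-4-yl on an aromatic carbon.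

The measured steps at this same place give the best guide. Two large steps, beyond the scatter, lead to the 1H-imidazol-4-yl group: a 13-fold higher number from compound 1 to compound 3 (1.11 log units; beyond the scatter) and a 14-fold higher number from compound 2 to compound 3 (1.13 log units; beyond the scatter). The remaining step stays within the scatter: a 1.1-fold lower number from compound 1 to compound 2 (0.02 log units; within the scatter). Going by these compounds, compound 4 also loses the 1H-imidazol-4-yl group, so a similarly large move to a lower number is expected in this assay, although thiophen-3-yl itself is untested. The expected change is a 12-fold lower number from compound 3 to compound 4 (1.09 log units; beyond the scatter). For compound 4, the estimated value is 1300 nM, with an expected range of 500 nM to 3500 nM.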

Compound 4, half-maximal effective concentration: 1930 nM
Compound 4: middle estimate off by 1.5-fold (0.17 log units), on the low side; the range from low to high includes it.
By their numbers in this assay, from the lowest: compounds 2, 1 and 4 (each within the scatter of the next); then compound 3.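

In this assay, thiophen-3-yl gives an 8.3-fold lower number from compound 3 to compound 4 (0.92 log units; beyond the scatter), so a five-membered aromatic ring holding sulfur and no nitrogen also avoids the high number seen with 1H-imidazol-4-yl. Two further steps place this group level with the other two: a 1.6-fold higher number from compound 2 to compound 4 (0.21 log units; within the scatter) and a 1.6-fold higher number from compound 1 to compound 4 (0.19 log units; within the scatter) are both within the usual scatter, which leaves compound 3 alone among the four and shows that a five-membered ring as such does not bring the high number. The hydrogen-bond donor that 1H-imidazol-4-yl carries and thiophen-3-yl lacks is a counted difference only, as no measurement shown gives a reason for the gap.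

The compounds shown leave open whether a plain phenyl ring or 1-methyl-1H-imidazol-4-yl would sit with compound 3 or with the other three. They also do not tell how a carboxylic acid or an amine at this place would read.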